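The compounds below may be only part of what the source reports. "The series", "measured", "known", "first", "only" and "open" are said of these compounds alone.

Compound 1 `CN(C)c1cccc(C(=O)N[C@H]2CCC[C@H](NC(=O)c3cccc(Cl)c3)C2)c1` — in a functional assay on HEK293 cells for antagonist activity at metabotropic glutamate receptor 5 (Homo sapiens), read by FLIPR and calcium flux (a higher number here means a weaker inhibitor, a lower number a stronger inhibitor), compound 1 gives > 10000 nM, which is a limit of the assay rather than a number.
Compound 2 `N#Cc1cccc(C(=O)N[C@H]2CCC[C@H](NC(=O)c3ccccn3)C2)c1` — compound 2 gives > 10000 nM, also a limit.
Compound 3 `O=C(N[C@H]1CCC[C@H](NC(=O)c2cccc(F)c2)C1)c1cccc(F)c1` — compound 3 gives 593 nM.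

Compound 1 therefore stands at the limit of > 10000 nM in this assay, at which 2 of the 3 values shown sit; only compound 3, with a fluorophenyl on each amide, gives a measured number. Compound 4 `Cc1cccnc1C(=O)N[C@H]1CCC[C@H](NC(=O)c2cccc(Cl)c2)C1` differs from compound 1 in one place: 3-methylpyridin-2-yl in place of 3-(dimethylamino)phenyl on a carbonyl carbon. Among the compounds with values here, no measured pair shows what such a change does here, so the step in this assay can be expected only loosely, with no direction beyond the scatter claimed. Compound 4 is estimated at 8000 nM (range 1500 nM to 40000 nM), a step of an at least 1.2-fold lower number from compound 1 to compound 4 (0.09 log units; that floor lies within the scatter), with a real chance of another limit.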

Compound 4, half-maximal inhibitory concentration: 7840 nM
Beside the measured number, compound 4's estimate is 1.0-fold (0.01 log units) above it; the range from low to high includes it.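

In this assay, putting 3-methylpyridin-2-yl in place of 3-(dimethylamino)phenyl on a carbonyl carbon gives an at least 1.2-fold lower number from compound 1 to compound 4 (0.10 log units; that floor lies within the scatter). Going by these compounds, compound 1 gives > 10000 nM, a limit of the assay, so the true size of this step stays unknown. Compound 4 keeps the other amide of compound 1 and still gives a measured number, against this background: the limit of > 10000 nM in this assay, at which 2 of the 4 values shown sit.

The compounds shown leave open whether the methyl group of 3-methylpyridin-2-yl matters to this number. They also leave open how a methoxy group or a longer chain such as ethyl would behave in its place.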